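Extending the Hydroxyalkyl Chain on a Shared Core

The source may hold more compounds than are shown below. What is called first, only, known or untested is meant among the compounds shown, and "the series" means these compounds.

Compounds measured so far:
Compound 1 `CCCCCCCCn1[nH]c2ccccc2c1=O`: in an assay on isolated protein (urine) for inhibition of Myeloperoxidase (Homo sapiens), read by spectrophotometry (a lower number here means a stronger inhibitor, a higher number a weaker inhibitor), compound 1 gives > 10000 nM, which is a limit of the assay rather than a number.
Compound 2 `O=c1c2ccccc2[nH]n1CCO`: in this assay compound 2 gives 2470 nM.

Among the measured compounds shown here, compound 2 holds the only actual number among the two values; the other value is a limit (the limit of > 10000 nM in this assay, at which 1 of the 2 values shown sits). For the measured compounds named here, the one measured step, an at least 4.0-fold lower number from compound 1 to compound 2 (0.60 log units; beyond the scatter), replaces hexyl with hydroxy on the chain carbon two bonds from the aromatic nitrogen.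

Compound 3 `O=c1c2ccccc2[nH]n1CCCO` carries the change (hydroxymethyl in place of hydroxy on a saturated chain carbon, two bonds along the chain from an aromatic nitrogen). This lengthens the hydroxyalkyl chain by one carbon while keeping the hydroxy end. The measured step swaps groups of very different kind on that carbon and does not directly show what one added carbon does. The expectation is therefore a step of about a 1.0-fold higher number from compound 2 to compound 3 (0.01 log units; within the scatter), within the usual scatter. The estimate for compound 3 in this assay is 2500 nM, with a range from 800 nM to 8000 nM.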

Compound 3, half-maximal inhibitory concentration: 1950 nM
Beside the measured number, compound 3's estimate is 1.3-fold (0.11 log units) above it; the range from low to high includes it.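

In this assay, lengthening the chain by one carbon while keeping the hydroxy end, from 2-hydroxyethyl to 3-hydroxypropyl, gives a 1.3-fold lower number from compound 2 to compound 3 (0.10 log units; within the scatter), so at this position the added carbon makes no difference that can be told apart from the scatter. The longer hydroxy-ended chain also stays clearly apart from the long chain of compound 1, with an at least 5.1-fold lower number from compound 1 to compound 3 (0.70 log units; beyond the scatter). The size of that step is only a lower bound, set by the value of compound 1, which is a limit of the assay and not a number: the limit of > 10000 nM in this assay, at which 1 of the 3 values shown sits.

The compounds shown leave open how far the chain can grow with its hydroxy end kept, as with a 4-hydroxybutyl chain. They also leave open whether the hydroxy itself matters, a question that an amine or a carboxylic acid at the chain end would address.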